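This account rests on a few compounds, and the source may have more. Where it says the series, first, only, none or still open, it means among the compounds named here.

Compound 3 `COc1ccc(NC(=S)Nc2ccc3[nH]ccc3c2)cc1` is the middle member of a small set of thioureas built on one shared core. In an ADME assay on isolated protein for inhibition of peroxidase (Raphanus sativus), read by fluorescence and Amplex Red, tested at 5 uM (a lower number here means a stronger effect, a higher number a weaker effect of the compound at the concentration tested), compound 3 gives 67.6%, the second highest of the three numbers. The unsubstituted parent, compound 1 `S=C(Nc1ccccc1)Nc1ccc2[nH]ccc2c1`, gives 81.4% in this assay, while compound 2 `Oc1ccccc1NC(=S)Nc1ccc2[nH]ccc2c1` gives 43.9%. Both steps from the parent run downward: a number 37.5 percentage points lower from compound 1 to compound 2 (beyond the scatter), and a number 13.8 percentage points lower from compound 1 to compound 3 (beyond the scatter).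

Compound 4 `CCOC(=O)c1ccc(NC(=S)Nc2ccc3[nH]ccc3c2)cc1` has not yet been measured. It differs from compound 3 in one place: ethoxycarbonyl in place of methoxy on an aromatic carbon. Neither measured step shows this exchange; the closest bearing is the step from compound 1 to compound 3, which put the methoxy group onto the same ring and shifted the number modestly, and the step from compound 1 to compound 2 shows that a second oxygen-bearing group moved the number much further. A group of five heavy atoms with two acceptors replacing one of two heavy atoms gives no firm direction, so a step that is at most modest, probably downward, is expected for compound 4, namely a number 7.6 percentage points lower from compound 3 to compound 4 (within the scatter). On that basis compound 4 is estimated at 60%, with a range from 40% to 80%.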

Compound 4, a percentage reported as activity, at one concentration (the size of the read-out at that concentration, not a potency): 65.8%
Estimate against measurement, compound 4: 5.8 percentage points below; low and high end bracket the measured number.
By their numbers in this assay, from the lowest: compound 2; then compounds 4 and 3 (each within the scatter of the next); then compound 1.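

In this assay, the exchange on this aromatic carbon, para to a large group, gives a number 1.8 percentage points lower from compound 3 to compound 4 (within the scatter), so ethoxycarbonyl and methoxy cannot be told apart here, even though the entering group has more heavy atoms and a double bond outside aromatic rings. Ethoxycarbonyl in place of hydrogen gives a number 15.6 percentage points lower from compound 1 to compound 4 (beyond the scatter), which shows that methoxy is not the only group at this position to stand apart from the unsubstituted compound 1, by a step of modest size. Nothing available explains why these two groups read alike.

From the compounds shown here alone, it remains open how a carboxylic acid or an amine at this position would read. Going by these compounds, it is also open whether hydroxy, the group of compound 2, would give as large a step here as it does in compound 2.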